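The source may report more compounds than this note shows. Statements on the series, on what has been measured and on what is new or still open speak of the compounds shown alone.

In a functional assay on the whole organism with Mus musculus as the target (on this read-out higher numbers stand for an effect only at larger amounts of compound and lower numbers for an effect already at smaller amounts), two compounds have been measured so far:

- Compound 1 `CCCCC(C)NCC(N)=O` gives 640 mg/kg
- Compound 2 `CNC(=O)[C@@H](C)NCc1ccc(OCc2ccccc2)cc1` gives 40.5 mg/kg

Compound 2 holds the lower of the two numbers, so in this assay it shows its effect at smaller amounts than compound 1, and the gap lies beyond the scatter. Compound 3 `CNC(=O)[C@H](NCc1ccc(OCc2ccccc2)cc1)C(C)C` has not been measured yet. It differs from compound 2 by isopropyl in place of methyl on a saturated chain carbon bound to an amine nitrogen and a carbonyl carbon in an otherwise unchanged structure. Among the compounds with values here, no measured pair shows what this change does, so the expectation starts from compound 2 at 40.5 mg/kg and stays cautious. A modest move toward a higher number is expected, with the estimated step of a 1.4-fold higher number from compound 2 to compound 3 (0.13 log units; within the scatter) not beyond the scatter. For compound 3 the estimated value is 55 mg/kg with an expected range from 20 mg/kg to 150 mg/kg for the coming measurement.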

Compound 3, dose for half-maximal effect: 112 mg/kg
Estimate against measurement, compound 3: 2.0-fold (0.31 log units) below; low and high end bracket the measured number.
By their numbers in this assay, from the lowest: compound 2; then compound 3; then compound 1.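

Within the data shown here, compound 2 and compound 3 form the first pair that differs in one place, so the effect of a change on the saturated chain carbon bound to an amine nitrogen and a carbonyl carbon can now be read directly. In this assay, isopropyl in place of methyl gives a 2.8-fold higher number from compound 2 to compound 3 (0.44 log units; beyond the scatter) and therefore a real, modest loss: more compound is needed for the same effect, so this position is sensitive to what sits on it. The data shown offer no measured explanation for this step.

From the compounds shown here alone, with only methyl and isopropyl to compare, it remains open whether ethyl would fall between them or whether phenyl or hydroxymethyl would shift the number further. Going by these compounds, it also remains open whether the same swap would have a similar effect on a different core.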